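One Methyl Group on a New Aromatic Carbon

The source may report more compounds than this note shows. Statements on the series, on what has been measured and on what is new or still open speak of the compounds shown alone.

In a physicochemical assay for lipophilicity (a lower number here means a more polar compound, a higher number a more lipophilic compound), compound 1 `CCC(=O)Oc1c(OC)c(OC)c(OC(=O)CC)c2ccccc12` gives 3.44. Compound 2 `CCC(=O)Oc1c(OC)c(OC)c(OC(=O)CC)c2c(OC)cccc12` gives the same figure, 3.44, while compound 3 `CCC(=O)Oc1c(OC)c(OC)c(OC(=O)CC)c2c(C)cccc12` reads higher at 3.9. Compound 1 therefore sits level with compound 2, and both lie under compound 3.

Compound 4 `CCC(=O)Oc1c(OC)c(OC)c(OC(=O)CC)c2cc(C)ccc12` has not been measured yet. Its difference from compound 1 is small: methyl in place of hydrogen on an aromatic carbon. In words, a methyl stands in place of a hydrogen on an aromatic carbon.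

The closest measured step is a number 0.46 log units higher from compound 1 to compound 3 (beyond the scatter). Within the data shown here, it is the same kind of swap, methyl in place of hydrogen, though on a different aromatic carbon from the one changed in compound 4. The other two steps say less, since each involves methoxy: no change at the digits printed from compound 1 to compound 2 (within the scatter), and a number 0.46 log units higher from compound 2 to compound 3 (beyond the scatter). Among the measured compounds shown here, with a single example of the swap, no measurement yet shows whether the place of the methyl matters.

With compound 3 at 3.9 as the guide, a rise of similar size is expected, and the estimated step reads a number 0.46 log units higher from compound 1 to compound 4 (beyond the scatter). For compound 4 the estimated value is 3.9, with an expected range from 3.6 to 4.2.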

Compound 4, partition coefficient: 3.9
For compound 4 middle estimate and measured number coincide at the digits printed; low and high end bracket the measured number.
By their numbers in this assay, from the lowest: compounds 1 and 2 (each within the scatter of the next); then compounds 3 and 4 (each within the scatter of the next).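

In this assay the swap of hydrogen for methyl now has a second example, and on this aromatic carbon, meta to a fused ring and para to a fused ring, it gives a number 0.46 log units higher from compound 1 to compound 4 (beyond the scatter) as a modest step. The earlier compounds could not show whether the place of the methyl matters, but compound 3 gives 3.9 and compound 4 gives 3.9 with the methyl on different aromatic carbons, so the two places shown cannot be told apart by this read-out. No measurement offered here gives a reason for the rise on going from hydrogen to methyl.

Two places are a small sample, so the compounds shown leave open whether a methyl on any other aromatic carbon of the core would give a similar number. They also leave open how this same carbon would read with a different group in place of the hydrogen, whether methoxy, a longer chain such as ethyl, an amine or a carboxylic acid, and so whether the size of the step follows the group at this position.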